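From furan-2-yl to thiophen-2-yl at an assay limit

The source may hold more compounds than are shown below. What is called first, only, known or untested is meant among the compounds shown, and "the series" means these compounds.

Measured in a functional assay on CEM-DNR-bulk cells (Homo sapiens), read by MTT assay, with a stated time of 72 h; a lower number here means a stronger inhibitor, a higher number a weaker inhibitor:
- compound 1 `COc1ncnc2c1c(-c1ccccc1)cn2[C@@H]1O[C@H](CO)[C@@H](O)[C@H]1O`: > 20000 nM (a limit)
- compound 2 `C#Cc1cn([C@@H]2O[C@H](CO)[C@@H](O)[C@H]2O)c2ncnc(OC)c12`: 3490 nM
- compound 3 `CNc1ncnc2c1c(-c1ccco1)cn2[C@@H]1O[C@H](CO)[C@@H](O)[C@H]1O`: > 20000 nM (a limit)

In this assay compound 3 gives only a limit, > 20000 nM, and so has no exact number. The same holds for compound 1, and the evidence so far is the limit of > 20000 nM in this assay, at which 2 of the 3 values shown sit. Only compound 2 has a measured number.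

Compound 4 `CNc1ncnc2c1c(-c1cccs1)cn2[C@@H]1O[C@H](CO)[C@@H](O)[C@H]1O` differs from compound 3 in one place: thiophen-2-yl in place of furan-2-yl on an aromatic carbon. Going by the values given here, one measured step bears on this only indirectly: an at least 5.7-fold lower number from compound 1 to compound 2 (0.75 log units; beyond the scatter). That step replaces phenyl with ethynyl, so it is a different exchange, and one end of it is a limit. Among the compounds with values here, no measured step swaps furan-2-yl for thiophen-2-yl. With so little to go on, no step beyond the scatter is expected in this assay, and another limit seems more likely than not. The estimate for compound 4 is 20000 nM, with an expected range of 5000 nM to 40000 nM. This expectation corresponds to an estimated a number no higher from compound 3 to compound 4 (the limit leaves the size open).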

Compound 4, half-maximal inhibitory concentration: > 20000 nM
Compound 4: no number, only a limit (the forecaster's own chance of this, stated with the estimate: 60%); the middle value lies on the limit itself.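

In this assay compound 3 and compound 4 both give only limits, so no step can be read between them, as the evidence shows: the limit of > 20000 nM in this assay, at which 3 of the 4 values shown sit.

The compounds shown leave open how furan-2-yl and thiophen-2-yl compare, since neither compound has an exact number.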